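Trading the methoxy arm for a methyl arm

The source may report more compounds than this note shows. Statements on the series, on what has been measured and on what is new or still open speak of the compounds shown alone.

Compound 1 `C=CCn1c(=O)/c(=C\c2cccc(Cl)c2)[nH]c(=O)/c1=C\c1ccccc1OC` gives 5200 nM in a functional assay on MCF7 cells (Homo sapiens) for cytotoxicity, read by CCK-8 assay, with a stated time of 72 h; a lower number here means a stronger inhibitor, a higher number a weaker inhibitor. Within the data shown here, compound 2 `C=CCn1c(=O)/c(=C\c2ccccc2OC)[nH]c(=O)/c1=C\c1ccccc1OC` carries two 2-methoxyphenyl groups and in this assay compound 2 gives 41100 nM, the higher of the two numbers; its only neighbour is compound 1, and the change between them is a 7.9-fold higher number from compound 1 to compound 2 (0.90 log units; beyond the scatter).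

Compound 3 `C=CCn1c(=O)/c(=C\c2cccc(C)c2)[nH]c(=O)/c1=C\c1ccccc1OC` has not yet been measured. It differs from compound 2 in one place: 3-methylphenyl in place of 2-methoxyphenyl on a double-bonded chain carbon bound to an aromatic carbon. Among the measured compounds shown here, the single step that bears on this change is the one from compound 1 to compound 2, a 7.9-fold higher number from compound 1 to compound 2 (0.90 log units; beyond the scatter), in which a 3-chlorophenyl gave way to a 2-methoxyphenyl and the number rose. Compound 3 brings in a 3-methylphenyl, closer in kind to the 3-chlorophenyl of compound 1 than to the 2-methoxyphenyl of compound 2, so a partial return toward the lower number of compound 1 seems the reasonable reading, with a methyl rather than a chlorine tempering the size of the move.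

Compound 3 is therefore expected to show a lower number than its parent, a step of about a 3.4-fold lower number from compound 2 to compound 3 (0.53 log units; beyond the scatter), because the step of a 7.9-fold higher number from compound 1 to compound 2 (0.90 log units; beyond the scatter) had gone the other way. The estimate for compound 3 in this assay is 12000 nM, with a range from 4000 nM to 35000 nM.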

Compound 3, half-maximal inhibitory concentration: 20700 nM
Compound 3: middle estimate off by 1.7-fold (0.24 log units), on the low side; the measured number falls inside the stated range.
By their numbers in this assay, from the lowest: compound 1; then compounds 3 and 2 (each within the scatter of the next).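

In this assay, the new compound separates two things that the first step had changed together, the group and where it sits. Among these compounds, with a 2.0-fold lower number from compound 2 to compound 3 (0.30 log units; within the scatter), the 3-methylphenyl and the 2-methoxyphenyl on the double-bonded chain carbon cannot be told apart, so in these three compounds a 3-methylphenyl does not recover the number of compound 1, while a 4.0-fold higher number from compound 1 to compound 3 (0.60 log units; beyond the scatter) lies beyond the scatter and shows that the exchange of chloro for methyl on the aromatic carbon is itself enough to register, with the lower number so far belonging to the 3-chlorophenyl alone. No measurement offered here gives a reason for either step.

The compounds shown leave open whether this lower number belongs to chloro in particular or would also appear with bromo, trifluoromethyl or a nitrile on the same aromatic carbon. They also leave open how far the number depends on the 2-methoxyphenyl that all three compounds share, and whether an amine or a carboxylic acid on that ring would keep or lose what the 3-chlorophenyl compound shows.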